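The compounds below may be only part of what the source reports. "The series", "measured", "known", "first", "only" and "open" are said of these compounds alone.

Of the compounds shown here, two of a shared core have been measured for cytotoxicity so far, and a third is considered on the basis of their numbers. Compound 1 `COc1ccc(-c2cc(-c3ccc4cc(F)ccc4n3)n(-c3ccc(F)cc3)n2)cc1` was tested in an ADME assay on Huh-7 cells (Homo sapiens) for cytotoxicity, read by XTT assay, with a stated time of 3 days, tested at 20 uM (on this read-out higher numbers stand for a weaker effect at the one concentration tested and lower numbers for a stronger effect), and compound 1 gives 98.8%. Compound 2 `COc1ccc(-n2nc(-c3ccc(F)cc3)cc2-c2ccc3cc(F)ccc3n2)cc1` was tested in the same way, and in this assay compound 2 gives 89.1%. Compound 2 thus stands with compound 1 at the weak end of the read-out, and the two numbers do not differ beyond the usual scatter of this kind of measurement, so neither can be called the more or less toxic of the pair.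

Compound 3 `COc1ccc(-c2cc(-c3ccc4cc(F)ccc4n3)n(-c3ccc(OC)cc3)n2)cc1` has not been measured. It differs from compound 2 in one place: methoxy in place of fluoro on an aromatic carbon. Going by the values given here, nothing among the measured compounds tells how such a change of fluoro to methoxy affects the read-out, so no step beyond the scatter is expected, and the step from compound 2 to compound 3 is estimated at a number 2.9 percentage points higher from compound 2 to compound 3 (within the scatter). On that basis compound 3 is expected to give about 92% in this assay, within a range from 76% to 104%.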

Compound 3, a percentage reported as activity, at one concentration (the size of the read-out at that concentration, not a potency): 95.8%
Beside the measured number, compound 3's estimate is 3.8 percentage points below it; the measured number falls inside the stated range.
By their numbers in this assay, from the lowest: compounds 2, 3 and 1 (each within the scatter of the next).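

Compound 3 carries the 4-methoxyphenyl group at both of the places where compound 1 and compound 2 each hold one 4-fluorophenyl group, so the same exchange can now be read twice on the shared core. In this assay the exchange of 4-fluorophenyl to 4-methoxyphenyl reads as a number 6.7 percentage points higher from compound 2 to compound 3 (within the scatter) at one place and as a number 3 percentage points lower from compound 1 to compound 3 (within the scatter) at the other, both within the scatter, so at neither place does methoxy in place of fluoro separate the compounds on this read-out, and all three stay at its weak end. No measurement at hand bears on why no step beyond the scatter appears at either place.

The compounds leave open whether any group at these two places would give a step beyond the scatter, for instance an amine or a carboxylic acid in place of the methoxy. Resting on one concentration, they also leave open how the three compounds would compare at other concentrations.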